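Same Sulfur-Chain Swap, Now on a Galloyl Amide

The source may report more compounds than this note shows. Statements on the series, on what has been measured and on what is new or still open speak of the compounds shown alone.

Of the compounds shown here, three have been measured in an assay on RAW264.7 cells for antagonist activity at Toll-like receptor 2 (Mus musculus), read by Griess assay, with a stated time of 24 h; on this read-out lower numbers stand for stronger inhibition and higher numbers for weaker inhibition. Compound 1 `C=CCCCSC[C@H](N)C(=O)OC` gives 31300 nM. Compound 2 `C#CCSC[C@H](N)C(=O)OC` gives 94400 nM. The change between them is ethynyl in place of but-3-en-1-yl on a saturated chain carbon bound to a sulfur, and the step it made is a 3.0-fold higher number from compound 1 to compound 2 (0.48 log units; beyond the scatter). Compound 3 `C=CCCCSC[C@H](NC(=O)c1cc(O)c(O)c(O)c1)C(=O)OC` carries a different core; the difference between the core of compound 1 and the core of compound 3 is not broken down here. In this assay compound 3 gives 39200 nM, which is within the scatter of compound 1 and beyond the scatter of compound 2.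

Compound 4 `C#CCSC[C@H](NC(=O)c1cc(O)c(O)c(O)c1)C(=O)OC` has not yet been measured. It relates to compound 3 exactly as compound 2 relates to compound 1: the change is ethynyl in place of but-3-en-1-yl on a saturated chain carbon bound to a sulfur, at the same place, so it is the same change. Within the data shown here, because the single earlier example of this change gave a 3.0-fold higher number from compound 1 to compound 2 (0.48 log units; beyond the scatter), the step is expected to be of a similar size, a 2.8-fold higher number from compound 3 to compound 4 (0.45 log units; beyond the scatter), though one example is a thin basis. On that basis compound 4 is estimated to give about 110000 nM, with a range from 50000 nM to 250000 nM.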

Compound 4, half-maximal inhibitory concentration: 71500 nM
Estimate against measurement, compound 4: 1.5-fold (0.19 log units) above; the measured number falls inside the stated range.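

In this assay the swap to ethynyl in place of but-3-en-1-yl, on a saturated chain carbon bound to a sulfur, reads a 1.8-fold higher number from compound 3 to compound 4 (0.26 log units; within the scatter) on this second core. Set beside the earlier case, the two steps do not differ by more than repeated measurements usually would: the same change on two cores in this assay, a 3.0-fold higher number (0.48 log units; beyond the scatter) from compound 1 to compound 2 and a 1.8-fold higher number (0.26 log units; within the scatter) from compound 3 to compound 4, 1.7-fold (0.22 log units) apart, within the scatter of two such steps. The change therefore appears to carry over from one core to the other in direction and roughly in size, but the new step alone cannot be told apart from ordinary scatter, and two pairs in one assay neither prove a general rule nor explain why the number moves.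

Going by these compounds, it remains open whether other groups on the sulfur, such as a plain methyl, a longer chain, or a chain ending in an amine, would follow the same trend on both cores. On these data alone, it also remains open whether the swap would give a similar step if the methyl ester were replaced by a carboxylic acid.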